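This account rests on a few compounds, and the source may have more. Where it says the series, first, only, none or still open, it means among the compounds named here.

Measured in a physicochemical assay for solubility, read by HPLC, in phosphate buffer, measured as kinetic solubility, with a stated time of 1 h, at pH 7.4, tested at 250 uM; on this read-out lower numbers stand for lower solubility and higher numbers for higher solubility:
- Compound 1 `O=C(NCCCCc1ccccc1)n1cc(-c2ccc(F)cc2)oc1=O` gives < 1000 nM, a limit.
- Compound 2 `O=C(NCCCCc1ccccc1)n1cc(-c2ccccn2)oc1=O` gives < 1000 nM, a limit.

Compound 2 therefore has no number in this series, and the limit of < 1000 nM in this assay, at which 2 of the 2 values shown sit, describes both values shown. Compound 3 `O=C(NCCCCc1ccccc1)n1cc(-c2ccncc2)oc1=O` carries pyridin-4-yl in place of pyridin-2-yl on an aromatic carbon, (pyridin-4-yl in place of pyridin-2-yl on an aromatic carbon). Among the measured compounds shown here, the only measured step, a step that the two limits leave unreadable from compound 1 to compound 2, gives no size to work from, so no step beyond the scatter is expected in this assay, and no direction is expected. The estimated step is a step that the limit leaves unreadable from compound 2 to compound 3. For compound 3 the expected value is 800 nM, with an estimated range of 250 nM to 4000 nM.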

Compound 3, solubility: < 1000 nM
Compound 3 was reported as a limit; the forecaster's own chance of this, stated with the estimate: 65%; the middle value lies beyond the limit too.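

No step among compound 1, compound 2 and compound 3 can be read in this assay, because all three sit at one limit: the limit of < 1000 nM in this assay, at which 3 of the 3 values shown sit.

On these data alone, whether 4-fluorophenyl, pyridin-2-yl and pyridin-4-yl differ at all on this read-out remains open.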